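This account rests on a few compounds, and the source may have more. Where it says the series, first, only, none or still open, it means among the compounds named here.

In a functional assay on BEAS-2B cells (Homo sapiens) for antiproliferative activity, read by CCK-8 assay, with a stated time of 24 h (a higher number here means a weaker inhibitor, a lower number a stronger inhibitor), three compounds have been measured, and each reads only as a limit. Compound 2 (`CC(C)(O)C1Cc2cc(C[C@H]3OC(=O)C(O)=C3c3ccc(O)cc3)ccc2O1`) gives the limit > 20000 nM. Compound 3 (`COC(=O)[C@]1(Cc2ccc(O)c(CC=C(C)C)c2)OC(=O)C(O)=C1c1ccc(O)c(CC=C(C)C)c1`) also gives only a limit, > 20000 nM. The set therefore shows (the limit of > 20000 nM in this assay, at which 3 of the 3 values shown sit). Compound 4 (`COC(=O)[C@]1(Cc2ccc(O)c(CC=C(C)C)c2)OC(=O)C(O)=C1c1ccccc1`) differs from compound 3 by phenyl in place of 4-hydroxy-3-(3-methylbut-2-en-1-yl)phenyl on a double-bonded ring carbon. Compound 1 (`COC(=O)[C@]1(Cc2ccc3c(c2)CC(C(C)(C)O)O3)OC(=O)C(O)=C1c1ccccc1`) already carries phenyl at that place, and its value is the limit > 20000 nM. The estimated change a step that the limit leaves unreadable from compound 3 to compound 4 in this assay is therefore expected to stay within the scatter, with no clear direction. The expected value for compound 4 is 25000 nM, within an estimated range of 12000 nM to 50000 nM.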

Compound 4, half-maximal inhibitory concentration: > 20000 nM
Compound 4 ended at the assay's limit (the forecaster's own chance of this, stated with the estimate: 80%); the middle value does not contradict the limit.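

Among these compounds, compound 3 and compound 4 both read only as limits in this assay, so no step between them can be read. The compounds shown leave open what real potency any of them has, all resting at one limit: the limit of > 20000 nM in this assay, at which 4 of the 4 values shown sit.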